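N6-style benzyl series: from compound 2 to compound 3

The source may hold more compounds than are shown below. What is called first, only, known or untested is meant among the compounds shown, and "the series" means these compounds.

Measured in a functional assay on CCRF-CEM cells (Homo sapiens) for antiproliferative activity, with a stated time of 72 h; on this read-out higher numbers stand for weaker inhibition and lower numbers for stronger inhibition:
- compound 1 `OC[C@H]1O[C@@H](n2cnc3c(NCc4ccccc4F)ncnc32)[C@H](O)[C@@H]1O`: 4600 nM
- compound 2 `OC[C@H]1O[C@@H](n2cnc3c(NCc4cccc(O)c4O)ncnc32)[C@H](O)[C@@H]1O`: "not determined" (no result reported)

Compound 2 has no place on the numbers: for compound 2 the entry reads ("not determined" (no result reported)), so no potency can be assigned to it and it cannot be ranked against compound 1. The next compound to be tested is compound 3 `Cc1ccc(O)c(CNc2ncnc3c2ncn3[C@@H]2O[C@H](CO)[C@@H](O)[C@H]2O)c1`, which keeps the shared core and changes only the benzyl part. The structural change is 2-hydroxy-5-methylphenyl in place of 2,3-dihydroxyphenyl on a saturated chain carbon bound to a nitrogen on an aromatic ring.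

With no number at its start, the step from compound 2 cannot be sized, and no direction can be read from it. The only anchor in this assay is compound 1 (4600 nM), and a result for compound 3 within the scatter of that value is expected, with no step beyond it. For compound 3 the estimated value is 4000 nM (expected range 1000 nM to 15000 nM).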

Compound 3, half-maximal inhibitory concentration: 1900 nM
The estimate for compound 3 lay 2.1-fold (0.32 log units) above the measured number, within the range that was stated.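

In this assay, the benzyl part of the series now has its first readable step: 2-hydroxy-5-methylphenyl in place of 2-fluorophenyl, on a saturated chain carbon bound to a nitrogen on an aromatic ring, gives a 2.4-fold lower number from compound 1 to compound 3 (0.38 log units; beyond the scatter), so the number at this place moves with the aryl group while the shared core stays fixed. Compound 2 has no result, so the step that leads from it cannot be read, and the exchange of 2,3-dihydroxyphenyl for 2-hydroxy-5-methylphenyl remains unsized. Nothing available bears on why the number falls with this change.

The compounds shown leave open whether the hydroxy or the methyl of 2-hydroxy-5-methylphenyl carries the step, as the two arrive together and only one pair can be compared. As far as these compounds go, how the read-out would respond to an amine or a carboxylic acid on the aromatic ring, or to a longer chain in place of the single saturated carbon, also remains open.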